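A few compounds are considered here, and "the series" means these few. Any claim that something is new, unique, unknown or untested is made for them only; others in the source may bear on it.

The study concerns three compounds that share a core in which a methylated naphthyl amine carries a guanidine-like unit linked to a second aromatic ring. Compound 1 `CN(C(=N)Nc1cccc2ccccc12)c1cccc2ccccc12` pairs two naphthyl rings; compound 2 `CCc1cccc(NC(=N)N(C)c2cccc3ccccc23)c1` has an ethyl-bearing phenyl ring instead; compound 3 `CN(C(=N)Nc1cccc([N+](=O)[O-])c1)c1cccc2ccccc12` carries a nitro group on that phenyl ring. In an assay on membranes from brain (Cavia porcellus) for binding affinity to Sigma non-opioid intracellular receptor 1 (Homo sapiens), read by radioligand binding (a higher number here means a weaker inhibitor, a lower number a stronger inhibitor), compound 1 gives 4800 nM, compound 2 gives 1000 nM, and compound 3 gives 2640 nM. For the measured compounds named here, compound 3 thus stands second highest of the three numbers, with compound 1 within the scatter of it, while the one documented single change, a 2.6-fold higher number from compound 2 to compound 3 (0.42 log units; beyond the scatter), is a modest step beyond the scatter.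

Compound 4 `CN(C(=N)Nc1cccc(N)c1)c1cccc2ccccc12` differs from compound 3 by amino in place of nitro on an aromatic carbon, the new group sitting on an aromatic carbon of a six-membered aromatic ring of carbon only, meta to a large group. Going by the values given here, no measured step exchanges one substituent at this spot for another polar one; the only step on this ring, from ethyl to nitro, was modest. Compound 4 is therefore expected to show no step beyond the scatter, a 1.1-fold lower number from compound 3 to compound 4 (0.02 log units; within the scatter), and its estimated value in this assay is 2500 nM, with a range from 900 nM to 7000 nM.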

Compound 4, half-maximal inhibitory concentration: 13000 nM
Estimate against measurement, compound 4: 5.2-fold (0.72 log units) below; measured number above the stated range.
By their numbers in this assay, from the lowest: compound 2; then compounds 3 and 1 (each within the scatter of the next); then compound 4.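

In this assay, the aromatic carbon meta to a large group proves sensitive to more than the single ethyl-to-nitro change had shown: amino in place of nitro gives a 4.9-fold higher number from compound 3 to compound 4 (0.69 log units; beyond the scatter), a second step beyond the scatter at this spot. Set against ethyl, the same amino group gives a 13-fold higher number from compound 2 to compound 4 (1.11 log units; beyond the scatter), the only large step among these compounds, so the three groups compared here fall in a clear order, with ethyl lowest, nitro in the middle and amino highest. No evidence is available to explain this order, and the numbers alone only describe it.

The compounds shown leave open whether the high number belongs to the amino group itself or would remain with a related group at this spot, such as an acetamide or a methylamine, and whether a hydroxyl or a methoxy group would sit closer to ethyl or to amino. They also leave open whether ethyl, nitro and amino keep this order on another aromatic carbon of the same ring.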